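Adding a chloro to compound 3

A few compounds are considered here, and "the series" means these few. Any claim that something is new, unique, unknown or untested is made for them only; others in the source may bear on it.

Values from a functional assay on L5178Y cells (Mus musculus) for cytotoxicity, read by MTT assay, with a stated time of 72 h (on this read-out higher numbers stand for weaker inhibition and lower numbers for stronger inhibition), are as follows:
compound 1 `COC(=O)c1c(O)cc(OC)c(Cl)c1Oc1c(C)cc(OC)cc1OC` gives > 10000 nM as a limit
compound 2 `COC(=O)c1c(O)cc(OC)c(Cl)c1Oc1c(C)cc(O)cc1OC` gives > 10000 nM as a limit
compound 3 `COc1cc(O)c(C(=O)c2c(C)cc(O)cc2OC)c(O)c1Cl` gives > 10000 nM as a limit

In this assay compound 3 has only the limit > 10000 nM and no number of its own. The whole series sits at the limit of > 10000 nM in this assay, at which 3 of the 3 values shown sit, and no order can be read among the three compounds.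

The next compound is compound 4 `COc1cc(O)cc(C)c1C(=O)c1c(O)c(Cl)c(OC)c(Cl)c1O` and it differs from compound 3 in one place only, by chloro in place of hydrogen on an aromatic carbon in the shared core. This is chloro in place of hydrogen on an aromatic carbon.

Among the compounds with values here, the only measured step is a step that the two limits leave unreadable from compound 1 to compound 2 and it is a different change, hydrogen in place of methyl on an oxygen on an aromatic ring. It therefore gives no size to carry over. Within the data shown here, no measured pair shows the chloro change, and no measured compound has a number to start from. In this assay no step beyond the scatter is therefore expected, and the data favour no direction. The estimated step is a step that the limit leaves unreadable from compound 3 to compound 4 and it remains an expectation resting on limits alone. Compound 4 is estimated at 12000 nM within an expected range of 4000 nM to 40000 nM on this read-out.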

Compound 4, half-maximal inhibitory concentration: > 10000 nM
Compound 4 was reported as a limit (the forecaster's own chance of this, stated with the estimate: 65%); the middle value lies beyond the limit too.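

In this assay compound 4 gives > 10000 nM, which is a limit. No step from compound 3 to compound 4 can be read, and all the compounds shown now stand at one value: the limit of > 10000 nM in this assay, at which 4 of the 4 values shown sit. The compounds shown leave open what size the chloro change has and whether any compound in this series has a measurable value in this assay.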